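From 4-Methoxyphenyl to 2-Chloropyridin-4-yl

The source may hold more compounds than are shown below. What is called first, only, known or untested is meant among the compounds shown, and "the series" means these compounds.

In a functional assay on MDA-MB-436 cells (Homo sapiens) for antiproliferative activity, read by MTT assay, with a stated time of 48 h (a higher number here means a weaker inhibitor, a lower number a stronger inhibitor), compound 1 `C=CS(=O)(=O)N1CCN(c2ccn3ncc(-c4ccccc4)c3n2)CC1` gives 19500 nM, compound 2 `C=CS(=O)(=O)N1CCN(c2ncnc3sc(-c4ccc(OC)cc4)cc23)CC1` gives 28400 nM and compound 3 `C=CS(=O)(=O)N1CCN(c2ncnc3sc(-c4cn(S(=O)(=O)c5ccccc5)c5ccccc45)cc23)CC1` gives 38000 nM. Compound 2 stands within the scatter of both other compounds, so these three values do not separate. Compound 4 `C=CS(=O)(=O)N1CCN(c2ncnc3sc(-c4ccnc(Cl)c4)cc23)CC1` carries 2-chloropyridin-4-yl in place of 4-methoxyphenyl on an aromatic carbon, next to the ring sulfur: 2-chloropyridin-4-yl in place of 4-methoxyphenyl on an aromatic carbon. Within the data shown here, no measured pair isolates a single change, so the data offer no direct guide to the size of this step. No shift beyond the scatter is therefore expected in this assay. The estimated change is a 1.3-fold lower number from compound 2 to compound 4 (0.11 log units; within the scatter). For compound 4, the expected value is 22000 nM, with an estimated range of 8000 nM to 50000 nM.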

Compound 4, half-maximal inhibitory concentration: 30100 nM
Estimate against measurement, compound 4: 1.4-fold (0.14 log units) below; measured number inside the range.
By their numbers in this assay, from the lowest: compounds 1, 2, 4 and 3 (each within the scatter of the next).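

In this assay, 2-chloropyridin-4-yl in place of 4-methoxyphenyl on an aromatic carbon, next to the ring sulfur, gives a 1.1-fold higher number from compound 2 to compound 4 (0.03 log units; within the scatter). Among these compounds, this is the first step here that isolates one place, and the two compounds do not separate, even though a six-membered aromatic ring of carbon only gives way to one with a hetero atom. Nothing available explains this result.

On these data alone, whether any group at this position would move the number beyond the scatter stays open. An aliphatic amine or a carboxylic acid on the aryl ring would test this.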